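This account rests on a few compounds, and the source may have more. Where it says the series, first, only, none or still open, it means among the compounds named here.

Within the data shown here, compound 2 `CCCC[S+]([O-])c1sc2nc(-c3nccs3)cc(-c3ccc(C(C)(C)O)cc3)c2c1N` gives 3.6 nM in an assay for inhibition of 15-hydroxyprostaglandin dehydrogenase [NAD(+)] (Homo sapiens), read by fluorescence, with a stated time of 15 min, in the presence of a further agent that is not named here (on this read-out higher numbers stand for weaker inhibition and lower numbers for stronger inhibition), the lowest of the two numbers so far, and compound 1 `CCCC[S+]([O-])c1sc2nc(-c3nccs3)cc(-c3ccc(C(=O)N(C)C)cc3)c2c1N` gives 5.9 nM, with the step of a 1.6-fold lower number from compound 1 to compound 2 (0.21 log units; within the scatter) staying within the scatter. Compound 3 `CCCC[S+]([O-])c1sc2nc(-c3nccs3)cc(-c3ccc(COC(=O)CN(C)C)cc3)c2c1N` changes the group on an aromatic carbon once more: ((((dimethylamino)methyl)carbonyl)oxy)methyl in place of 1-hydroxy-1-methylethyl on an aromatic carbon. Among the measured compounds shown here, the only measured step that bears on this exchange is a 1.6-fold lower number from compound 1 to compound 2 (0.21 log units; within the scatter), an exchange of groups on an aromatic carbon without a step beyond the scatter. On that single comparison the expectation for compound 3 is no step beyond the scatter, a 1.4-fold higher number from compound 2 to compound 3 (0.14 log units; within the scatter). Compound 3 is therefore estimated at 5 nM, between 1.5 nM and 20 nM.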

Compound 3, half-maximal inhibitory concentration: 3.5 nM
Compound 3: middle estimate off by 1.4-fold (0.15 log units), on the high side, and the stated range covers the measured number.
By their numbers in this assay, from the lowest: compounds 3, 2 and 1 (each within the scatter of the next).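

In this assay, the ((((dimethylamino)methyl)carbonyl)oxy)methyl group, the larger of the two groups in the exchange, shows a 1.0-fold lower number from compound 2 to compound 3 (0.01 log units; within the scatter) and a 1.7-fold lower number from compound 1 to compound 3 (0.23 log units; within the scatter). This position on the aromatic carbon, para to a large group, therefore carries this longer chain with no step beyond the scatter, so the three groups shown do not separate. No measurement here offers an explanation for this result.

Still open, as far as these compounds go, is whether this position responds to any group at all. A carboxylic acid, a primary amine or plain hydrogen there would test this.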